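The source may report more compounds than this note shows. Statements on the series, on what has been measured and on what is new or still open speak of the compounds shown alone.

In a functional assay on A549 cells (Homo sapiens) for antiproliferative activity, read by sulforhodamine B assay, with a stated time of 48 h (on this read-out lower numbers stand for stronger inhibition and higher numbers for weaker inhibition), compound 1 `COc1ccc(/C=C/C(=O)c2ccccc2-c2ccc(OC)c(OC)c2)cc1` gives 1600 nM, while compound 2 `COc1ccc(/C=C/C(=O)c2ccccc2-c2ccc(OC)c(OC)c2)cc1OC` gives 8500 nM. The two differ by methoxy in place of hydrogen on an aromatic carbon, and that change made a step of a 5.3-fold higher number from compound 1 to compound 2 (0.73 log units; beyond the scatter). Compound 3 `COc1ccc(C(=O)/C=C/c2ccccc2-c2ccc(F)cc2)cc1` gives 8200 nM in this assay; the difference between its core and the core of compound 1 is not broken down here. Compound 4 `COc1ccc(C(=O)/C=C/c2ccccc2-c2ccc(F)cc2)cc1OC` has not yet been measured. It differs from compound 3 by methoxy in place of hydrogen on an aromatic carbon, the same change, at the same place, that turned compound 1 into compound 2. Because that earlier step was a 5.3-fold higher number from compound 1 to compound 2 (0.73 log units; beyond the scatter), a step in the same direction is expected here, and the expected step is a 3.7-fold higher number from compound 3 to compound 4 (0.56 log units; beyond the scatter), though it rests on a single precedent in a different core, so the range is kept wide. Compound 4 is therefore estimated at 30000 nM in this assay, between 8000 nM and 100000 nM.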

Compound 4, half-maximal inhibitory concentration: 7500 nM
Beside the measured number, compound 4's estimate is 4.0-fold (0.60 log units) above it; the whole stated range lies above it.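

In this assay, methoxy in place of hydrogen on an aromatic carbon gave a 1.1-fold lower number from compound 3 to compound 4 (0.04 log units; within the scatter), so the clear step seen on the other core did not return. The change therefore did not carry over between these two cores: the same change on two cores in this assay, a 5.3-fold higher number (0.73 log units; beyond the scatter) from compound 1 to compound 2 and a 1.1-fold lower number (0.04 log units; within the scatter) from compound 3 to compound 4, 5.8-fold (0.76 log units) apart, beyond the scatter of two such steps. The size of this step depends on the core in these two pairs, but two pairs cannot show which difference between the cores is responsible, or how a third core would respond.

The compounds shown leave open how a hydroxyl group, an amine or a longer chain such as ethoxy would behave in place of this methoxy. From the compounds shown here alone, whether such groups would also give different steps on the two cores remains unknown.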